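Fluoro for Methyl on a Shared Core: an Expected Dose

This account rests on a few compounds, and the source may have more. Where it says the series, first, only, none or still open, it means among the compounds named here.

In a functional assay on the whole organism (strain NMRI) with Mus musculus as the target, with a stated time of 4 h (a lower number here means that less compound is needed, a higher number that more compound is needed for the effect), the three measured compounds stand as follows:
compound 1 `Cc1ccc(Cn2cc(CO/N=C/c3c(-c4ccc(F)cc4)nc4ccc(Br)cn34)nn2)cc1` gives 100 mg/kg;
compound 2 `Cc1ccc(Cn2cc(CO/N=C/c3c(-c4ccc(C)cc4)nc4ccc(Br)cn34)nn2)cc1` gives 100 mg/kg;
compound 3 `Cc1ccc(-c2nc3c(C)cccn3c2/C=N/OCc2cn(Cc3ccc(C#N)cc3)nn2)cc1` gives 100 mg/kg.

All three values stand level with one another within the scatter. Compound 1 and compound 2 share one core and differ only in the change (fluoro in place of methyl on an aromatic carbon); that change made the step of no change at the digits printed from compound 2 to compound 1 (within the scatter). Compound 3 carries a different core; how the core of compound 3 differs from the core of compound 2 is not broken down here, and only their two values, which agree, can be set side by side.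

Compound 4 `Cc1cccn2c(/C=N/OCc3cn(Cc4ccc(C#N)cc4)nn3)c(-c3ccc(F)cc3)nc12` is not yet measured. It arises from compound 3 by the change (fluoro in place of methyl on an aromatic carbon), the same change, at the same kind of place, that turned compound 2 into compound 1. On that earlier step, no change at the digits printed from compound 2 to compound 1 (within the scatter), the expectation rests: the step from compound 3 to compound 4 is estimated as no change at the digits printed from compound 3 to compound 4 (within the scatter).

Compound 4 is therefore expected to give about 100 mg/kg in this assay, estimated to lie between 50 mg/kg and 200 mg/kg.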

Compound 4, minimum effective dose: 40 mg/kg
Beside the measured number, compound 4's estimate is 2.5-fold (0.40 log units) above it, outside the stated range (below it).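

In this assay, replacing 4-methylphenyl with 4-fluorophenyl gave a 2.5-fold lower number from compound 3 to compound 4 (0.40 log units; beyond the scatter). Set against the earlier use of the same change, the two results cannot be told apart: the same change on two cores in this assay, no change at the digits printed (within the scatter) from compound 2 to compound 1 and a 2.5-fold lower number (0.40 log units; beyond the scatter) from compound 3 to compound 4, 2.5-fold (0.40 log units) apart, within the scatter of two such steps. This means that the change can be carried from one core to the other without a measurable disagreement between the two steps, but it does not show that the steps are truly equal, and one pair of compounds on each core is too little to predict the result on any further core.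

The compounds shown leave open how other groups in the same place on the aromatic ring, such as chloro, methoxy, trifluoromethyl or an amine, would compare with fluoro and methyl in this assay. They also leave open whether the fluoro for methyl change would give a similar step on a core carrying a longer chain or a carboxylic acid.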